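A few compounds are considered here, and "the series" means these few. Any claim that something is new, unique, unknown or untested is made for them only; others in the source may bear on it.

Compound 1 `N#Cc1ccc(Nc2nc(Oc3ccnc4ccccc34)nc(N3CCN(c4ccccc4Cl)CC3)n2)cc1C(F)(F)F` is one of two close relatives tested in a functional assay on DU-145 cells (Homo sapiens) for cytotoxicity, read by sulforhodamine B assay, with a stated time of 48 h; a lower number here means a stronger inhibitor of growth, a higher number a weaker inhibitor of growth. There compound 1 gives > 100000 nM, which is a limit of the assay rather than a number. Compound 2 `N#Cc1ccc(Nc2nc(Oc3ccnc4ccccc34)nc(N3CCN(c4ccccn4)CC3)n2)cc1C(F)(F)F` likewise gives > 100000 nM, again a limit. Within the data shown here, the step that the two limits leave unreadable from compound 1 to compound 2 therefore cannot be read, and the one piece of evidence is the limit of > 100000 nM in this assay, at which 2 of the 2 values shown sit. Compound 3 `N#Cc1ccc(Nc2nc(Oc3ccnc4ccccc34)nc(N3CCN(c4ccccc4F)CC3)n2)cc1C(F)(F)F` differs from compound 1 by fluoro in place of chloro on an aromatic carbon. With no readable step to guide it, the expected step is a number no higher from compound 1 to compound 3 (the limit leaves the size open), with compound 3 expected to sit at about 100000 nM, within 20000 nM to 300000 nM.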

Compound 3, concentration for total growth inhibition: > 100000 nM
Compound 3 gave a limit, no number; the forecaster's own chance of this, stated with the estimate: 80%; the middle value lies on the limit itself.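

Compound 3 also stops at a limit of the assay, so neither step to it, from compound 1 or from compound 2, can be read in this assay. The compounds shown leave open how these three compare in growth inhibition, since all of them rest on the same limit: the limit of > 100000 nM in this assay, at which 3 of the 3 values shown sit.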